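This account rests on a few compounds, and the source may have more. Where it says the series, first, only, none or still open, it means among the compounds named here.

Measured in a physicochemical assay for lipophilicity, read by HPLC, at pH 7.5; on this read-out higher numbers stand for higher lipophilicity and lower numbers for lower lipophilicity:

- compound 1 `CC[C@@H](Nc1c(C#N)c(-c2ccc(-c3cccc(Cl)c3OC)cc2)nc2cnccc12)C(N)=O`: 3.1
- compound 2 `CCOc1ccccc1-c1ccc(-c2nc(NC(C)C(=O)O)c3ccncc3n2)cc1`: 2.1
- compound 3 `CCOc1ccccc1-c1ccc(-c2nc3cnccc3c(N[C@H](CC)C(=O)O)c2C#N)cc1`: 2.1

Compound 1 holds the highest of the three numbers in this assay; compound 2 and compound 3 both sit lower, each beyond the scatter of the measurement. Compound 4 `CC[C@@H](Nc1c(C#N)c(-c2ccc(-c3ccccc3NC)cc2)nc2cnccc12)C(N)=O` has not yet been measured in this assay. It differs from compound 1 in one place, on an aromatic carbon of a six-membered aromatic ring of carbon only, para to a large group: 2-(methylamino)phenyl in place of 3-chloro-2-methoxyphenyl on an aromatic carbon. Among the compounds with values here, no step between two measured compounds covers this change, so the size of the step rests on expectation alone. A downward step beyond the scatter is expected in this assay, the step from compound 1 to compound 4 being estimated at a number 0.80 log units lower from compound 1 to compound 4 (beyond the scatter). Compound 4 is therefore expected to give 2.3 in this assay, within a range of 1.8 to 2.8.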

Compound 4, distribution coefficient: 2.5
Compound 4: middle estimate off by 0.20 log units, on the low side; measured number inside the range.
By their numbers in this assay, from the lowest: compounds 2 and 3 (each within the scatter of the next); then compound 4; then compound 1.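

In this assay, within the data shown here, 2-(methylamino)phenyl in place of 3-chloro-2-methoxyphenyl gives a number 0.60 log units lower from compound 1 to compound 4 (beyond the scatter) and is the first step read at this position, on an aromatic carbon para to a large group. The swap removes chlorine and methoxy and adds methylamino together, so this single step cannot be divided among them. No measurement at hand accounts for the step. From the compounds shown here alone, how much of it belongs to the chlorine and how much to the ring's other substituent remains open. Equally open, going by these compounds, is what 2-methoxyphenyl, 2-aminophenyl or unsubstituted phenyl would give on the same core.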